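Silyl ether series: methoxymethoxy analogue of compound 2

The source may report more compounds than this note shows. Statements on the series, on what has been measured and on what is new or still open speak of the compounds shown alone.

Measured so far:
- compound 1 `COc1ccc(C2=C(c3cc(OC)c(OC)c(OC)c3)C(=O)C(OC(C)=O)C2)cc1F`, in an ADME assay on HT-29 cells (Homo sapiens) for cytotoxicity, read by MTT assay, with a stated time of 72 h; a lower number here means a stronger inhibitor, a higher number a weaker inhibitor: < 1 ug/mL, a limit of the assay
- compound 2 `COc1ccc(C2=C(c3cc(OC)c(OC)c(OC)c3)C(=O)CC2O[SiH2]C(C)(C)C)cc1OC`, in this assay: > 100 ug/mL, a limit of the assay
- compound 3 `COc1ccc(C2=C(c3cc(OC)c(OC)c(OC)c3)C(=O)C(OC(C)=O)C2)cc1Cl`, in this assay: < 1 ug/mL, a limit of the assay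

Compound 2 stands at the weak end of what has been measured. Its value in this assay is a limit only, so the true number is not known; it sits at the limit of > 100 ug/mL in this assay, at which 1 of the 3 values shown sits. Among the compounds with values here, the other two compounds sit at the limit of < 1 ug/mL in this assay, at which 2 of the 3 values shown sit, and the only step that can be computed, a step that the two limits leave unreadable from compound 1 to compound 3, is unreadable for the same reason.

Compound 4 `COCOc1cc(C2=C(c3cc(OC)c(OC)c(OC)c3)C(=O)CC2O[SiH2]C(C)(C)C)ccc1OC` differs from compound 2 by methoxy in place of hydrogen on a saturated chain carbon bound to an oxygen on an aromatic ring. Cut one bond further out, this reads methoxy to methoxymethoxy. Within the data shown here, no measured step bears on this change: the one computed step concerns a chloro in place of fluoro and is itself unreadable, and compound 2 carries only a limit. There is therefore no measured basis for a step in either direction beyond the scatter.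

Compound 4 is expected to remain near the limit of compound 2, with a number no higher from compound 2 to compound 4 (the limit leaves the size open) as the estimated step. The estimate for compound 4 in this assay is 100 ug/mL, within 30 ug/mL to 300 ug/mL.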

Compound 4, half-maximal inhibitory concentration: 43 ug/mL
Compound 4: the middle estimate sits 2.3-fold (0.37 log units) above what was measured, within the range that was stated.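

Compound 2 carries > 100 ug/mL, a limit of the assay. Extending methoxy to methoxymethoxy, with everything else in the structure unchanged, gives an at least 2.3-fold lower number from compound 2 to compound 4 (0.36 log units; beyond the scatter) in this assay, the only readable step in the series so far, as the earlier chloro in place of fluoro step cannot be read; this position therefore accepts the longer group with a real change in the number, and the direction is towards the stronger end. The size of the step has only a lower bound, and how much further the true gap runs stays unknown since compound 2 stands at a limit: the limit of > 100 ug/mL in this assay, at which 1 of the 4 values shown sits.

The compounds shown leave open whether a free hydroxyl at this oxygen, or a longer chain such as 2-methoxyethoxy, would move the number further in the same direction or reverse it. They also leave open whether the methoxymethoxy change would have any readable effect on the core of compound 1, and whether an amine at this position would be accepted at all.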